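Compound 4: methyl in place of nitro

The source may hold more compounds than are shown below. What is called first, only, known or untested is meant among the compounds shown, and "the series" means these compounds.

In a functional assay on MCF7 cells (Homo sapiens) for cytotoxicity, read by MTT assay, with a stated time of 48 h (a higher number here means a weaker inhibitor, a lower number a stronger inhibitor), compound 2 `O=[N+]([O-])c1ccc(NC(=S)N/N=C\c2ccnc3ccccc23)cc1` gives 810 nM and sits level, within the scatter, with compound 1 `CCc1ccc(NC(=S)N/N=C\c2ccnc3ccccc23)cc1` at 820 nM and compound 3 `S=C(N/N=C\c1ccnc2ccccc12)Nc1cccc2ccccc12` at 880 nM on the same read-out. The step to compound 4 `Cc1ccc(NC(=S)N/N=C\c2ccnc3ccccc23)cc1` is methyl in place of nitro on an aromatic carbon, para to a large group (methyl in place of nitro on an aromatic carbon). Going by the values given here, the one measured step bearing on it is nitro in place of ethyl (a 1.0-fold lower number from compound 1 to compound 2 (0.01 log units; within the scatter)) and it lies within the scatter, so no step beyond the scatter is expected in this assay for methyl. The expected step is small and without a clear direction (a 1.0-fold higher number from compound 2 to compound 4 (0.01 log units; within the scatter)). Compound 4 is estimated at 820 nM with 450 nM to 1500 nM as the expected range.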

Compound 4, half-maximal inhibitory concentration: 980 nM
Compound 4: the middle estimate sits 1.2-fold (0.08 log units) below what was measured; measured number inside the range.
By their numbers in this assay, from the lowest: compounds 2, 1, 3 and 4 (each within the scatter of the next).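

In this assay, the swap of nitro for methyl gives a 1.2-fold higher number from compound 2 to compound 4 (0.08 log units; within the scatter), and hydrogen in place of methyl on the chain carbon gives a 1.2-fold higher number from compound 1 to compound 4 (0.08 log units; within the scatter). Nitro, ethyl and methyl at this position therefore all lie within the scatter of one another, so neither group swap nor chain trimming separates these compounds. Nothing measured here speaks to why this position is so flat.

Going by these compounds, whether an amine, a carboxylic acid or a longer chain such as butyl at this same place would give a step beyond the scatter stays open.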